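Urea-to-amide swap on a pyrazole core

This account rests on a few compounds, and the source may have more. Where it says the series, first, only, none or still open, it means among the compounds named here.

Measured so far:
compound 1 `COc1cc(Cl)cc(-c2nn(-c3cccc(NC(=O)Nc4ccc(Cl)c(C(F)(F)F)c4)c3)cc2-c2ccncc2)c1`: 340 nM
compound 2 `COc1cc(Cl)cc(-c2nn(-c3cccc(NC(=O)Nc4ccc(Cl)c(Cl)c4)c3)cc2-c2ccncc2)c1`: 1130 nM

For the measured compounds named here, compound 2 gives the higher of the two numbers in a functional assay on PC-3 cells (Homo sapiens) for inhibition, read by sulforhodamine B assay, with a stated time of 48 h (a lower number here means a stronger inhibitor, a higher number a weaker inhibitor), with compound 1 as its only neighbour, and the step from the one to the other was a 3.3-fold higher number from compound 1 to compound 2 (0.52 log units; beyond the scatter). Compound 3 `COc1cc(Cl)cc(-c2nn(-c3cccc(NC(=O)c4cccc(C(F)(F)F)c4)c3)cc2-c2ccncc2)c1` is made from compound 2 by a single change: 3-(trifluoromethyl)phenyl in place of (3,4-dichlorophenyl)amino on a carbonyl carbon. Going by the values given here, only the step from compound 1 to compound 2 bears on this, and only in part, since it changed one substituent of the ring while the urea linkage stayed; the present change removes the amide-type nitrogen of the linkage altogether, and no measured pair speaks to that. A change of this kind is therefore taken as uncertain, and a weaker inhibitor is expected, with compound 3 estimated at 2200 nM (range 500 nM to 9000 nM), a step of a 1.9-fold higher number from compound 2 to compound 3 (0.29 log units; within the scatter).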

Compound 3, half-maximal inhibitory concentration: 2710 nM
Estimate against measurement, compound 3: 1.2-fold (0.09 log units) below, and the stated range covers the measured number.
By their numbers in this assay, from the lowest: compound 1; then compound 2; then compound 3.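

In this assay, taking the amide-type nitrogen out of the linkage cost activity beyond the scatter, with a 2.4-fold higher number from compound 2 to compound 3 (0.38 log units; beyond the scatter) as 3-(trifluoromethyl)phenyl replaced (3,4-dichlorophenyl)amino on the carbonyl carbon. The step is larger against the urea that already carries a trifluoromethyl group, at an 8.0-fold higher number from compound 1 to compound 3 (0.90 log units; beyond the scatter), so keeping that group on the ring did not preserve the activity of the urea once the nitrogen and its hydrogen-bond donor were gone. No measurement offered here accounts for this loss.

The compounds shown do not separate the part played by the missing nitrogen from the part played by the lost ring chlorine, as both changed together in each step. Going by these compounds, it also remains open whether a methylene group in place of that nitrogen, or a 4-chloro-3-(trifluoromethyl)phenyl directly on the carbonyl carbon, would restore activity.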